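Working notes: cell toxicity stays at the ceiling

The source may report more compounds than this note shows. Statements on the series, on what has been measured and on what is new or still open speak of the compounds shown alone.

All three measured compounds stop at the ceiling of a functional assay on K562 cells (Homo sapiens) for inhibition, read by sulforhodamine B assay, with a stated time of 48 h; on this read-out higher numbers stand for lower toxicity in this test and lower numbers for higher toxicity in this test. Compound 1 `O=C(Nc1cccc(-n2cc(-c3ccncc3)c(-c3ccc(Cl)c(O)c3)n2)c1)Nc1cccc(C(F)(F)F)c1` gives > 32500 nM, a limit rather than a number. Compound 3 `O=C(Nc1cccc(-n2cc(-c3ccncc3)c(-c3ccc(Cl)c(O)c3)n2)c1)Nc1cc(C(F)(F)F)cc(C(F)(F)F)c1` gives > 50000 nM, also a limit. For the measured compounds named here, the only one-place step in the set, a step that the two limits leave unreadable from compound 1 to compound 3, therefore cannot be read; the limit of > 32500 nM in this assay, at which 1 of the 3 values shown sits, and the limit of > 50000 nM in this assay, at which 2 of the 3 values shown sit, mark where the values stop. Compound 2 `COc1cc(-c2nn(-c3cccc(NC(=O)c4cccc(C(F)(F)F)c4)c3)cc2-c2ccncc2)ccc1Cl`, the amide of the set, gives > 50000 nM in this assay, again a limit. Compound 2 thus stands at the ceiling alongside the two ureas and cannot be ranked against them.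

Compound 4 `COc1cc(-c2nn(-c3cccc(NC(=O)Nc4ccc(Cl)c(C(F)(F)F)c4)c3)cc2-c2ccncc2)ccc1Cl` is not yet measured. Its change from compound 2 is (4-chloro-3-(trifluoromethyl)phenyl)amino in place of 3-(trifluoromethyl)phenyl on a carbonyl carbon, which turns the amide of compound 2 into a urea of the kind carried by compound 1 and compound 3. Going by the values given here, no measured step bears on this change directly, since the single measured step has limits at both ends. With every measured compound, urea or amide alike, sitting at a limit, no shift beyond the scatter is expected in this assay. Compound 4 is expected to give 60000 nM, with a range from 20000 nM to 200000 nM, and most likely to be reported once more as a limit. The expected step that the limit leaves unreadable from compound 2 to compound 4 is accordingly nil within the scatter.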

Compound 4, concentration lethal to 50% of the cells: > 32500 nM
Compound 4: a limit, no number; the forecaster's own chance of this, stated with the estimate: 80%; the middle value is on the limit's open side.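

Compound 4, like compound 2, stops at a limit in this assay, not at a number, so the step between compound 2 and compound 4 cannot be read. The compounds shown leave open what concentration, if any, of these ureas and this amide would reach a readable value in this assay, and so whether the change to the urea shifts it.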